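Oxygen-to-sulfur swap in the ring on the sulfonyl chain

This account rests on a few compounds, and the source may have more. Where it says the series, first, only, none or still open, it means among the compounds named here.

The series is followed in a functional assay, tested at 100 ug/mL; on this read-out lower numbers stand for a weaker effect and higher numbers for a stronger effect at the one concentration tested. Compound 2 `O=S(=O)(CC1=NCCO1)C1C(c2ccc(Cl)cc2)=NOC1c1ccc(Cl)cc1` gives "not active" (no number reported), so no single number stands against it; one further member of the set, compound 1 `O=S(=O)(CC1=NCCO1)C1=NNCC1c1ccccc1`, also closes without a number, giving "not active" (no number reported). Going by the values given here, the only numbered member is compound 3 `COc1ccc(-c2noc(-c3ccc(C)cc3)c2S(=O)(=O)CC2=NCCO2)cc1`, which in this assay reaches 77.1%; its core and its aryl groups differ from those of compound 2 in more than one place, so no step between the two is set out, and the two readings can only be set side by side. No pattern across the three is claimed.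

Compound 4 `O=S(=O)(CC1=NCCS1)C1C(c2ccc(Cl)cc2)=NOC1c1ccc(Cl)cc1` is the untested partner of compound 2. The change from compound 2 to compound 4 is a group of 5 heavy atoms (3 carbon, 1 nitrogen, 1 sulfur; one five-membered non-aromatic ring with 2 hetero atoms) in place of a group of 5 heavy atoms (3 carbon, 1 nitrogen, 1 oxygen; one five-membered non-aromatic ring with 2 hetero atoms), on a saturated chain carbon bound to a sulfonyl sulfur

Among the compounds with values here, no measured step of this kind exists in the set, so the size of the step in this assay is open. Given that compound 2 returns "not active" (no number reported), and that the change keeps the ring size, the count of hetero atoms and the count of acceptors, the expectation is a step of no size beyond the usual scatter, in no set direction. Compound 4 is accordingly expected to give about 12% in this assay, within a range of 0% to 40%, and most likely to be reported again without a number.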

Compound 4, a percentage reported as activity, at one concentration (the size of the read-out at that concentration, not a potency): "not active" (no number reported)
Nothing numeric was reported for compound 4, and the estimate cannot be compared.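

In this assay compound 2 and compound 4 both close without a number, so no step can be read for this swap of the ring on the sulfonyl chain. Nothing measured here bears on a cause for the result. The compounds shown leave open whether the same swap changes the reading on the core of compound 3, which gives 77.1%.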